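This account rests on a few compounds, and the source may have more. Where it says the series, first, only, none or still open, it means among the compounds named here.

Three compounds have been measured in a functional assay on PC-3 cells (Homo sapiens) for inhibition; a higher number here means a weaker inhibitor, a lower number a stronger inhibitor:

Compound 1 `COc1cc2nc(N3CCN(S(=O)(=O)c4ccc(Br)cc4)CC3)nc(N)c2cc1OC` gives 20000 nM.
Compound 2 `COc1cc2nc(N3CCN(S(=O)(=O)c4ccc(Cl)s4)CC3)nc(N)c2cc1OC` gives 25000 nM.
Compound 3 `COc1cc2nc(N3CCN(S(=O)(=O)c4ccc(OC(F)(F)F)cc4)CC3)nc(N)c2cc1OC` gives 25000 nM.

All three share the same core and differ only in the aromatic group attached to the sulfonyl sulfur. Compound 3 stands level with compound 2 at the digits shown, and together they carry the highest numbers of the three; compound 1 is the furthest from compound 3, and even that gap is small: a 1.3-fold higher number from compound 1 to compound 3 (0.10 log units; within the scatter). Likewise no change at the digits printed from compound 2 to compound 3 (within the scatter) and a 1.3-fold higher number from compound 1 to compound 2 (0.10 log units; within the scatter).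

Compound 4 `COc1cc2nc(N3CCN(S(=O)(=O)c4ccc(N)cc4N)CC3)nc(N)c2cc1OC` is the next step. Relative to compound 3 the change is 2,4-diaminophenyl in place of 4-(trifluoromethoxy)phenyl on a sulfonyl sulfur. Going by the values given here, the steps that bear on it are the two exchanges of the aromatic group on the sulfonyl sulfur, and both left this assay unmoved: no change at the digits printed from compound 2 to compound 3 (within the scatter) and a 1.3-fold higher number from compound 1 to compound 3 (0.10 log units; within the scatter). Among the compounds with values here, none of the measured groups, however, brings hydrogen-bond donors, so the new 2,4-diaminophenyl group has no direct precedent here. On the evidence available, no step beyond the scatter is expected, and the estimate for compound 4 is 25000 nM, with a range from 8000 nM to 70000 nM, which means an expected step of no change at the digits printed from compound 3 to compound 4 (within the scatter).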

Compound 4, half-maximal inhibitory concentration: 67000 nM
The estimate for compound 4 lay 2.7-fold (0.43 log units) below the measured number; low and high end bracket the measured number.
By their numbers in this assay, from the lowest: compounds 1, 2 and 3 (each within the scatter of the next); then compound 4.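

In this assay, the group on the sulfonyl sulfur now proves able to move the number: the exchange for 2,4-diaminophenyl gives a 2.7-fold higher number from compound 3 to compound 4 (0.43 log units; beyond the scatter) and a 2.7-fold higher number from compound 2 to compound 4 (0.43 log units; beyond the scatter) and a 3.4-fold higher number from compound 1 to compound 4 (0.53 log units; beyond the scatter) in the three comparisons, whereas the exchanges among the first three groups all stayed within the scatter. Going by these compounds alone, the shift is towards weaker inhibition, which makes compound 4 the weakest inhibitor of the four, and 2,4-diaminophenyl is the only group of the four that carries hydrogen-bond donors, though one compound cannot tie the step to those donors rather than to some other difference between the groups. Nothing measured here accounts for the step.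

As far as these compounds go, it stays open whether both amino groups are needed, which a 4-aminophenyl or a 2-aminophenyl group on the sulfonyl sulfur would help to separate, and whether a hydroxy or an acetamido group would shift the number the same way. The compounds shown also do not say whether any group at this place can bring the number well under those of compounds 1, 2 and 3.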